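Extending a methylamino chain on a pyrazoline amide

The source may report more compounds than this note shows. Statements on the series, on what has been measured and on what is new or still open speak of the compounds shown alone.

Measured so far:
- compound 1, `CCC(=O)N1N=C(c2cc3ccccc3oc2=O)CC1c1ccccc1`: 4370 nM
- compound 2, `Cc1ccc(S(=O)(=O)N2N=C(c3cc4ccccc4oc3=O)CC2c2ccccc2)cc1`: 48600 nM
- compound 3, `CNCC(=O)N1N=C(c2cc3ccccc3oc2=O)CC1c1ccccc1`: 2300 nM

In a functional assay on PC-3 cells (Homo sapiens) for cytotoxicity, read by MTT assay, with a stated time of 48 h (on this read-out higher numbers stand for weaker inhibition and lower numbers for stronger inhibition), compound 3 gives the lowest of the three numbers. Its nearest neighbour is compound 1, a step of a 1.9-fold lower number from compound 1 to compound 3 (0.28 log units; within the scatter); compound 2 lies far off, a step of a 21-fold lower number from compound 2 to compound 3 (1.32 log units; beyond the scatter). The change from compound 3 to compound 4, `CCNCC(=O)N1N=C(c2cc3ccccc3oc2=O)CC1c1ccccc1`, is methyl in place of hydrogen on a saturated chain carbon bound to an amine nitrogen. Among the compounds with values here, none of the measured steps touches that position: the step of a 1.9-fold lower number from compound 1 to compound 3 (0.28 log units; within the scatter) introduced the methylamino group itself and stayed within the scatter, while the steps of an 11-fold higher number from compound 1 to compound 2 (1.05 log units; beyond the scatter) and a 21-fold lower number from compound 2 to compound 3 (1.32 log units; beyond the scatter) concern the group on the ring nitrogen and are large. Within the data shown here, with no measured step on the chain beyond the amine nitrogen, the account expects no change beyond the scatter for compound 4, that is a 1.1-fold higher number from compound 3 to compound 4 (0.04 log units; within the scatter). Compound 4 is therefore estimated at 2500 nM in this assay, within a range of 1000 nM to 6500 nM.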

Compound 4, half-maximal inhibitory concentration: 5580 nM
For compound 4 the middle estimate is 2.2-fold (0.35 log units) below the measured one; the range from low to high includes it.
By their numbers in this assay, from the lowest: compounds 3, 1 and 4 (each within the scatter of the next, the first and the last beyond it); then compound 2.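

In this assay the chain beyond the amine nitrogen turns out to be sensitive to a single added methyl: methylamino to ethylamino gives a 2.4-fold higher number from compound 3 to compound 4 (0.38 log units; beyond the scatter), a modest step. The ethylamino amide cannot be told apart from the propanoyl amide, with a 1.3-fold higher number from compound 1 to compound 4 (0.11 log units; within the scatter), yet it stays well clear of the sulfonamide, with an 8.7-fold lower number from compound 2 to compound 4 (0.94 log units; beyond the scatter), so the choice of group on the ring nitrogen still outweighs this change to the chain. Nothing available on these compounds explains the step from methylamino to ethylamino.

From the compounds shown here alone, whether a longer chain such as propylamino would move the number further in the same direction remains open. So does the effect of a dimethylamino group, or of a ring amine such as piperidine, at this position.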